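Extending the pyridyl side chain and buffer half-life

A few compounds are considered here, and "the series" means these few. Any claim that something is new, unique, unknown or untested is made for them only; others in the source may bear on it.

Three compounds have been measured in an ADME assay, in phosphate buffer, at 28 degrees C, at pH 7.0; a higher number here means that the compound lasts longer, a lower number that the compound disappears faster:
compound 1 `C[C@H](O)[C@H]1C(=O)N2C(C(=O)O)=C(C(C)(C)C)O[C@H]12` gives 7.1 h;
compound 2 `COC(=O)[C@H](O)[C@H]1C(=O)N2C(C(=O)O)=C(C(C)(C)C)O[C@H]12` gives 6.7 h;
compound 3 `CC(C)(C)C1=C(C(=O)O)N2C(=O)[C@H]([C@@H](O)c3ccncc3)[C@H]2O1` gives 6 h.

Compound 3 has the lowest of the three numbers, but the gaps to its neighbours are small: a 1.1-fold lower number from compound 2 to compound 3 (0.05 log units; within the scatter) and a 1.2-fold lower number from compound 1 to compound 3 (0.07 log units; within the scatter), both within the scatter. Compound 4 `CC(C)(C)C1=C(C(=O)O)N2C(=O)[C@H]([C@@H](O)CCc3ccncc3)[C@H]2O1` differs from compound 3 in one place: 2-(pyridin-4-yl)ethyl in place of pyridin-4-yl on a saturated chain carbon bound to an oxygen on a saturated carbon and a saturated ring carbon. The measured steps that bear on this change are those at the same position, a 1.1-fold lower number from compound 1 to compound 2 (0.03 log units; within the scatter), a 1.2-fold lower number from compound 1 to compound 3 (0.07 log units; within the scatter) and a 1.1-fold lower number from compound 2 to compound 3 (0.05 log units; within the scatter); none moved the half-life beyond the scatter. Compound 4 is therefore expected to stay close to compound 3, with a step of no change at the digits printed from compound 3 to compound 4 (within the scatter). The estimate for compound 4 is 6 h, within 3.5 h to 10 h.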

Compound 4, half-life: 15.8 h
Estimate against measurement, compound 4: 2.6-fold (0.42 log units) below; the measured number lies above the stated range.
By their numbers in this assay, from the lowest: compounds 3, 2 and 1 (each within the scatter of the next); then compound 4.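

Among the groups at this position, on a saturated chain carbon bound to an oxygen on a saturated carbon and a saturated ring carbon, only 2-(pyridin-4-yl)ethyl moves the half-life in this assay beyond the scatter (a 2.6-fold higher number from compound 3 to compound 4 (0.42 log units; beyond the scatter)). Compound 4 also stands clear of the others (a 2.4-fold higher number from compound 2 to compound 4 (0.37 log units; beyond the scatter); a 2.2-fold higher number from compound 1 to compound 4 (0.35 log units; beyond the scatter)). Nothing available explains this rise. The compounds shown leave open whether a longer chain carrying pyridin-4-yl would extend the half-life further. They also leave open whether 2-phenylethyl or an amine-bearing chain would match compound 4.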